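The source may hold more compounds than are shown below. What is called first, only, known or untested is meant among the compounds shown, and "the series" means these compounds.

Measured compounds in an assay on isolated protein for inhibition of Amine oxidase [flavin-containing] A (Homo sapiens), read by fluorescence and spectrophotometry, with a stated time of 20 min; on this read-out lower numbers stand for stronger inhibition and higher numbers for weaker inhibition:
compound 1 `O=C1CSc2cc(OCc3ccccc3)ccc2N1`, 8060 nM
compound 2 `O=C1CSc2cc(OCCCc3ccccc3)ccc2N1`, 96800 nM
compound 3 `COc1ccc2c(c1)SCC(=O)N2`, 21100 nM

Compound 3 stands second highest of the three numbers in this assay; compound 1 gives the nearest number, 8060 nM, and compound 2 the furthest, 96800 nM. Compound 4 `CCCOc1ccc2c(c1)SCC(=O)N2` differs from compound 3 by ethyl in place of hydrogen on a saturated chain carbon bound to an oxygen on an aromatic ring. Going by the values given here, the one measured step at this position is a 2.6-fold higher number from compound 1 to compound 3 (0.42 log units; beyond the scatter): removing the phenyl moved the number up by a modest amount. Between compound 1 and compound 2 no single step is shown; compound 1 gives 8060 nM and compound 2 gives 96800 nM, so the longer chain carrying the phenyl goes with a much higher number. The ethyl entering here is smaller than the phenyl removed in that step, so in this assay a step no larger than that one is expected, most likely a slight move downward or none beyond the scatter. For compound 4 the expected step is a 1.4-fold lower number from compound 3 to compound 4 (0.15 log units; within the scatter). Compound 4 is therefore estimated at 15000 nM in this assay, with a range from 5000 nM to 45000 nM.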

Compound 4, half-maximal inhibitory concentration: 6510 nM
The estimate for compound 4 lay 2.3-fold (0.36 log units) above the measured number; the measured number falls inside the stated range.
By their numbers in this assay, from the lowest: compounds 4 and 1 (each within the scatter of the next); then compound 3; then compound 2.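

In this assay, propoxy in place of methoxy gives a 3.2-fold lower number from compound 3 to compound 4 (0.51 log units; beyond the scatter), so a lower number at this position does not depend on a phenyl at the end of the chain. Ethyl in place of phenyl makes no difference beyond the scatter, with a 1.2-fold lower number from compound 1 to compound 4 (0.09 log units; within the scatter), and the plain propyl chain matches the benzyl group here. The phenyl's contribution depends on the chain that carries it, as a 15-fold lower number from compound 2 to compound 4 (1.17 log units; beyond the scatter) runs opposite to the step from removing the phenyl of compound 1: the same change on two cores in this assay, a 2.6-fold higher number (0.42 log units; beyond the scatter) from compound 1 to compound 3 and a 15-fold lower number (1.17 log units; beyond the scatter) from compound 2 to compound 4, 39-fold (1.59 log units) apart, beyond the scatter of two such steps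

Going by these compounds, it remains open whether the number keeps falling with a longer unbranched chain such as butyl or hexyl, or what a branched chain would do. Also open, on these data alone, is how a chain ending in an amine or a carboxylic acid would read.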